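The compounds below may be only part of what the source reports. "The series", "measured", "known", "first", "only" and "open" are said of these compounds alone.

Measured in a toxicity assay on THP-1 cells (Homo sapiens) for inhibition; on this read-out lower numbers stand for higher toxicity in this test and higher numbers for lower toxicity in this test:
Compound 1 `COc1ccc(-c2cnc(NC(=O)CCc3ccccc3)n2C)cc1` gives > 100000 nM, a limit of the assay.
Compound 2 `COc1ccc(-c2cnc(NC(=O)C3CCOCC3)n2C)cc1` gives > 100000 nM, a limit of the assay.
Compound 3 `COc1ccc(-c2cnc(NC(=O)c3cnco3)n2C)cc1` gives > 100000 nM, a limit of the assay.

Going by the values given here, compound 3 stands only at a limit in this assay; (the limit of > 100000 nM in this assay, at which 3 of the 3 values shown sit), so no compound has a readable number. The step to compound 4 `COc1ccc(-c2cnc(NC(=O)C3CCNCC3)n2C)cc1` is piperidin-4-yl in place of 1,3-oxazol-5-yl on a carbonyl carbon. Among the compounds with values here, the steps that bear on it, a step that the two limits leave unreadable from compound 1 to compound 3 and a step that the two limits leave unreadable from compound 2 to compound 3, as well as a step that the two limits leave unreadable from compound 1 to compound 2, are all unreadable because of the limits; no size of any change at the carbonyl carbon has yet been seen. Therefore no step beyond the scatter can be expected for compound 4 in this assay, and the estimate for compound 4 is 100000 nM (range 40000 nM to 250000 nM), meaning an expected step of a number no higher from compound 3 to compound 4 (the limit leaves the size open) from compound 3, most probably again reported only as a limit.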

Compound 4, half-maximal cytotoxic concentration: > 100000 nM
Compound 4 gave a limit, no number; the forecaster's own chance of this, stated with the estimate: 85%; the middle value sits exactly at the limit.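

In this assay compound 4 stands at a limit, as do compound 1, compound 2 and compound 3, so none of the steps among them can be read: the limit of > 100000 nM in this assay, at which 4 of the 4 values shown sit.

The compounds shown leave open what size of step any change on the carbonyl carbon gives in this assay.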